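Cytotoxicity notes: compound 2 to compound 4

The source may report more compounds than this note shows. Statements on the series, on what has been measured and on what is new or still open speak of the compounds shown alone.

Measured in an ADME assay on cells (Homo sapiens) for cytotoxicity (a higher number here means that more compound is tolerated, a lower number that less compound is tolerated), so far:
- compound 1 `O=C1N(Cc2ccccc2COc2ccc(-c3ccc(Cl)cc3)cc2)CCN1c1ccncc1`: > 1250 nM
- compound 2 `O=C1N(CCC(CCOc2ccc(-c3ccc(Cl)cc3)cc2)C(F)(F)F)CCN1c1ccncc1`: > 12500 nM
- compound 3 `CC(C)(CCCOc1ccc(-c2ccc(Cl)cc2)cc1)CN1CCN(c2ccncc2)C1=O`: 20000 nM

The value for compound 1 is a limit of the assay, not a number. The value for compound 2 is likewise a limit and not a number. Compound 3 alone gives a numeric reading. Where compound 2 stands is therefore known only as a limit: it sits at the limit of > 12500 nM in this assay, at which 1 of the 3 values shown sits. Compound 1 sits at the limit of > 1250 nM in this assay, at which 1 of the 3 values shown sits. Among the compounds with values here, no step between measured compounds that differ in one place is available, so nothing measured speaks to the size of a single change.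

Compound 4 `CCC(CCOc1ccc(-c2ccc(Cl)cc2)cc1)CCN1CCN(c2ccncc2)C1=O` has not yet been measured. It differs from compound 2 by ethyl in place of trifluoromethyl on a saturated chain carbon bound to two saturated chain carbons.

Within the data shown here, no measured step fits this change, and no direction is set by the data. The expectation is that the step from compound 2 to compound 4 amounts to a step that the limit leaves unreadable from compound 2 to compound 4, that is, nothing beyond the scatter. For compound 4 the estimated reading in this assay is 15000 nM, with a range from 5000 nM to 40000 nM, and a fair chance that the assay again reports only a limit.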

Compound 4, half-maximal cytotoxic concentration: > 25000 nM
Compound 4 was reported as a limit; the forecaster's own chance of this, stated with the estimate: 50%; middle value at least 1.6-fold (0.22 log units) from the limit.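

Compound 4 gives > 25000 nM, which is a limit of the assay and not a number. Compound 2 also stands only as a limit, so the step from compound 2 to compound 4 cannot be read. On these data alone, whether ethyl in place of trifluoromethyl on a saturated chain carbon bound to two saturated chain carbons changes the tolerated concentration remains open.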